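The source may report more compounds than this note shows. Statements on the series, on what has been measured and on what is new or still open speak of the compounds shown alone.

Working notes on the series. Compound 1 `CC(=O)c1ccc(OCCCN2CCN(c3ncccn3)CC2)cc1` is assessed in a functional assay on L5178Y cells (Mus musculus) for cytotoxicity, read by MTT assay; on this read-out lower numbers stand for stronger inhibition and higher numbers for weaker inhibition. In this assay compound 1 gives > 100 nM, which is a limit of the assay rather than a number. Where compound 1 stands is therefore known only through (the limit of > 100 nM in this assay, at which 1 of the 3 values shown sits). Two other members carry a numeric result. Compound 2 `CC(=O)c1ccc(OCCCCN2CCN(c3ccccn3)CC2)cc1` gives 63.7 nM in this assay. Compound 3 `CCC(C)(C)c1ccc(OCCCCN2CCN(c3cccnc3)CC2)cc1` gives 9.23 nM in this assay. Among the measured compounds shown here, neither of them differs from compound 1 in one place only, so no single step back to compound 1 can be read from either; they show only that numeric values well inside the measured range occur.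

The next compound, compound 4 `CC(=O)c1ccc(OCCCN2CCN(c3ccncc3)CC2)cc1`, is not yet measured. It differs from compound 1 in one place: pyridin-4-yl in place of pyrimidin-2-yl on an amine nitrogen in a ring. For the measured compounds named here, no measured pair in the set isolates this exchange, so the size of the step rests on expectation alone. The step from compound 1 to compound 4 in this assay is expected to be small and toward stronger inhibition, a number no higher from compound 1 to compound 4 (the limit leaves the size open), largely because compound 1 is fixed no more closely than the limit of > 100 nM in this assay, at which 1 of the 3 values shown sits. For compound 4 the estimate in this assay is 100 nM, with a range from 35 nM to 300 nM, and a real chance that the assay again returns only a limit.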

Compound 4, half-maximal inhibitory concentration: > 100 nM
Compound 4: no number, only a limit (the forecaster's own chance of this, stated with the estimate: 45%); the middle value lies on the limit itself.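

In this assay, among the compounds shown here, compound 4, like compound 1, returns only a limit of the assay, so no step for pyridin-4-yl in place of pyrimidin-2-yl can be read between the two: the limit of > 100 nM in this assay, at which 2 of the 4 values shown sit. The compounds shown leave open how far either compound lies beyond that limit, and whether this exchange changes inhibition at all.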